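Swapping Cyano for Methoxy on Compound 1

The source may report more compounds than this note shows. Statements on the series, on what has been measured and on what is new or still open speak of the compounds shown alone.

Measured so far in a physicochemical assay for solubility, at pH 7.4; on this read-out lower numbers stand for lower solubility and higher numbers for higher solubility:
- compound 1 `N#Cc1cccc(Nc2cc(C3CC3)c(C(=O)NCC3CCOCC3)cn2)c1` gives 4 ug/mL
- compound 2 `O=C(NCC1CCOCC1)c1cnc(Nc2ccc(Cl)cc2Cl)cc1C1CCCC1` gives < 1 ug/mL, a limit of the assay and not a number
- compound 3 `CC(C)(O)c1cc(Nc2ccc(Cl)cc2Cl)ncc1C(=O)NCC1CCOCC1` gives 150 ug/mL

Among the compounds with values here, only two of these values are true numbers, and compound 1 holds the lower one. Compound 3 stands clearly higher, by a gap well beyond the usual scatter of repeated measurements.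

Compound 4 `COc1cccc(Nc2cc(C3CC3)c(C(=O)NCC3CCOCC3)cn2)c1` has not been measured yet. It differs from compound 1 in a single place: methoxy in place of cyano on an aromatic carbon. In words, methoxy takes the place of cyano on an aromatic carbon, and the rest of the molecule stays the same.

Within the data shown here, only one measured step compares two compounds directly, an at least 150-fold higher number from compound 2 to compound 3 (2.17 log units; beyond the scatter), with 1-hydroxy-1-methylethyl in place of cyclopentyl. That step is large, so a single change can move this read-out a long way. However, it involves other groups at another place on the molecule, so it says little about this swap. The best guide is therefore compound 1 itself at 4 ug/mL.

No step beyond the scatter is expected in this assay, and the estimated change is a 1.3-fold higher number from compound 1 to compound 4 (0.10 log units; within the scatter). For compound 4 the expected value is 5 ug/mL, within an estimated range from 1.5 ug/mL to 15 ug/mL.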

Compound 4, solubility: 168 ug/mL
Compound 4: middle estimate off by 34-fold (1.53 log units), on the low side; measured number above the stated range.
By their numbers in this assay, from the lowest: compound 1; then compounds 3 and 4 (each within the scatter of the next). At a limit, below all of these: compound 2.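

In this assay the swap of cyano for methoxy gives a 42-fold higher number from compound 1 to compound 4 (1.62 log units; beyond the scatter) and so shows that this place, on the carbon-only aromatic ring and meta to a large group, is far from a quiet spot on the molecule. Within the data shown here, until now the only large step seen, an at least 150-fold higher number from compound 2 to compound 3 (2.17 log units; beyond the scatter), came from a change at another place, so a large move at this place is new information. The edit itself looks small on paper, since cyano and methoxy each carry 2 heavy atoms, 1 hydrogen-bond acceptor, 0 hydrogen-bond donors and no net charge, and nothing shown here accounts for a move of this size.

As far as these compounds go, with only cyano and methoxy to compare at this place, it stays open whether an amine, a carboxylic acid or a longer chain such as ethoxy would land close to compound 4 or close to compound 1. Also open, from the compounds shown here alone, is whether the same swap would bring a step of similar size on a molecule that differs elsewhere, such as one carrying a cyclopentyl group in the other position that changed between compound 2 and compound 3.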